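The source may report more compounds than this note shows. Statements on the series, on what has been measured and on what is new or still open speak of the compounds shown alone.

Going by the values given here, compound 2 `COC[C@H](C(C)C)C(c1ccc(O)c(OC)c1)c1ccc(O)c(OC)c1` gives 72000 nM in a functional assay on HL-60 cells (Homo sapiens) for cytotoxicity, read by WST assay, with a stated time of 48 h (a higher number here means a weaker inhibitor, a lower number a stronger inhibitor), the second highest of the three numbers known. Compound 1 `COC[C@H](C)[C@H](C)C(c1ccc(O)c(OC)c1)c1ccc(O)c(OC)c1` gives 82000 nM and compound 3 `COc1cc(C(c2ccc(O)c(OC)c2)[C@@H](C)C(C)C)ccc1O` gives 20000 nM. The step of a 1.1-fold lower number from compound 1 to compound 2 (0.06 log units; within the scatter) shows that swapping the two chain arrangements changes little, whereas the step of a 3.6-fold lower number from compound 2 to compound 3 (0.56 log units; beyond the scatter) shows that losing the methoxy gives a modest gain. Compound 4 `COc1cc(C(c2ccc(O)c(OC)c2)[C@H](C)[C@@H](C)CO)ccc1O` differs from compound 2 by 2-(hydroxymethyl)-1-methylpropyl in place of 1-(methoxymethyl)-2-methylpropyl on a saturated chain carbon bound to two aromatic carbons. Among the compounds with values here, its chain arrangement matches compound 1, which suggests little shift, while the hydroxymethyl in place of the methoxymethyl has no measured counterpart here. The step from compound 2 to compound 4 is therefore expected to be small, a 1.2-fold lower number from compound 2 to compound 4 (0.08 log units; within the scatter). Compound 4 is estimated at 60000 nM, within a range of 25000 nM to 150000 nM.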

Compound 4, half-maximal inhibitory concentration: > 100000 nM
Compound 4: no number, only a limit (the forecaster's own chance of this, stated with the estimate: 10%); at least 1.6-fold (0.22 log units) between middle value and limit.
By their numbers in this assay, from the lowest: compound 3; then compounds 2 and 1 (each within the scatter of the next). At a limit, above all of these: compound 4.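

Compound 4, with its hydroxymethyl, has no number, only a limit: the limit of > 100000 nM in this assay, at which 1 of the 4 values shown sits. The step of an at least 5.0-fold higher number from compound 3 to compound 4 (0.69 log units; beyond the scatter) clears the scatter, so the hydroxyl form joins compounds 1 and 2: every chain carrying oxygen gives a higher number than the 1,2-dimethylpropyl of compound 3. The floors of the steps of an at least 1.3-fold higher number from compound 2 to compound 4 (0.14 log units; that floor lies within the scatter) and an at least 1.2-fold higher number from compound 1 to compound 4 (0.08 log units; that floor lies within the scatter) lie within the scatter, so these steps do not separate hydroxymethyl from methoxymethyl. On these data alone, how an amine or a carboxylic acid in place of the hydroxymethyl, or a longer chain, would read stays open.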